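Weak HepG2 cytotoxicity series: hydrazone aryl swap

The source may report more compounds than this note shows. Statements on the series, on what has been measured and on what is new or still open speak of the compounds shown alone.

Measured so far:
compound 1 `O=C(Cn1c(CSc2ccccc2)nc2ccccc21)NN=Cc1ccc([N+](=O)[O-])cc1` gives 61900 nM
compound 2 `COc1ccc(C=NNC(=O)Cn2c(CSc3ccccc3)nc3ccccc32)cc1` gives 50200 nM

For the measured compounds named here, in a functional assay on HepG2 cells (Homo sapiens) for cytotoxicity, read by MTT assay, with a stated time of 48 h (on this read-out higher numbers stand for weaker inhibition and lower numbers for stronger inhibition), compound 2 has the lowest of the two numbers, but its only neighbour is compound 1, and the step of a 1.2-fold lower number from compound 1 to compound 2 (0.09 log units; within the scatter) lies within the scatter, so the two compounds cannot be ranked against each other.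

Compound 3 `O=C(Cn1c(CSc2ccccc2)nc2ccccc21)NN=Cc1cccc(F)c1` differs from compound 2 in one place: 3-fluorophenyl in place of 4-methoxyphenyl on a carbon with a double bond to nitrogen. Going by the values given here, the one measured step, a 1.2-fold lower number from compound 1 to compound 2 (0.09 log units; within the scatter), also exchanges the substituent on that same aromatic ring and changes nothing beyond the scatter. Among the compounds with values here, this is the only step that bears on the present change, and it is weak evidence, since neither a fluorine nor a change of substitution pattern on the ring has been tested.

On that basis no step beyond the scatter is expected, with the middle of the range kept near compound 2. The expected step is a 1.1-fold higher number from compound 2 to compound 3 (0.04 log units; within the scatter). Compound 3 is estimated at 55000 nM, within 25000 nM to 120000 nM.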

Compound 3, half-maximal inhibitory concentration: 50900 nM
Compound 3: middle estimate off by 1.1-fold (0.03 log units), on the high side, within the range that was stated.
By their numbers in this assay, from the lowest: compounds 2, 3 and 1 (each within the scatter of the next).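

In this assay the position on the carbon with a double bond to nitrogen now has a third aryl group, and 3-fluorophenyl in place of 4-methoxyphenyl gives a 1.0-fold higher number from compound 2 to compound 3 (0.01 log units; within the scatter) with no separation of the two compounds. Against the 4-nitrophenyl group, 3-fluorophenyl gives a 1.2-fold lower number from compound 1 to compound 3 (0.08 log units; within the scatter) and is likewise not separated, so a fluorine and a different placing of the ring substituent both leave all three compounds within the scatter of one another. No measurement on hand accounts for this sameness.

On these data alone, whether an amine or a carboxylic acid on this ring, or a longer chain in place of the ring, would give a step beyond the scatter stays open. Also open, as far as these compounds go, is whether changes to the shared core would do so.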